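The compounds below may be only part of what the source reports. "The series", "measured", "known", "first", "only" and "open" are said of these compounds alone.

Measured so far:
Compound 1 `CCc1ccc2[nH]c(=O)c(CN(Cc3ccc(O)cc3)Cc3ccc(C(C)(C)C)cc3)cc2c1`: > 10000 nM
Compound 2 `Cc1ccc2[nH]c(=O)c(CN(Cc3ccc(OCC(=O)O)cc3)Cc3ccc(C(C)(C)C)cc3)cc2c1`: > 10000 nM

In a toxicity assay on MDCK cells (Canis lupus familiaris) for cytotoxicity, read by crystal violet staining, with a stated time of 48 h (a lower number here means that less compound is tolerated, a higher number that more compound is tolerated), compound 1 reaches only a limit of the assay, > 10000 nM. Compound 2 likewise shows only a limit in this assay, > 10000 nM, so no number is known for it; both values sit at the same point, (the limit of > 10000 nM in this assay, at which 2 of the 2 values shown sit), and nothing separates them. Compound 2 therefore stands at the edge of what this assay can report, with no tolerated concentration actually resolved.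

Compound 3 `Cc1ccc2[nH]c(=O)c(CN(Cc3ccc(C#N)cc3)Cc3ccc(C(C)(C)C)cc3)cc2c1` is not yet measured. It differs from compound 2 in one place: cyano in place of carboxymethoxy on an aromatic carbon. The carboxymethoxy group leaves and a cyano group enters on the same aromatic carbon.

Among the measured compounds shown here, since every value shown is a limit, no measured step exists to lean on. The step that the limit leaves unreadable from compound 2 to compound 3 is expected to be small or none beyond the scatter. Compound 3 is estimated at 15000 nM, within 4000 nM to 60000 nM, most likely again reported only as a limit.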

Compound 3, half-maximal cytotoxic concentration: > 5000 nM
Compound 3 gave a limit, no number (the forecaster's own chance of this, stated with the estimate: 65%); the middle value is on the limit's open side.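

Compound 2 and compound 3 each give only a limit of the assay, and the step between them cannot be read. The compounds shown leave open what concentration any of them tolerates, and whether cyano in place of carboxymethoxy shifts it at all.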